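This account rests on a few compounds, and the source may have more. Where it says the series, first, only, none or still open, it means among the compounds named here.

Of the compounds shown here, three have been measured in a functional assay on A549 cells (Homo sapiens) for inhibition, read by MTT assay, with a stated time of 72 h; a lower number here means a stronger inhibitor, a higher number a weaker inhibitor. Compound 1, `COc1cc(O)cc(O)c1C(=O)/C=C/c1ccc([N+](=O)[O-])cc1`, gives only a limit there, > 50000 nM. Compound 2, `COc1cc(O)cc(O)c1C(=O)/C=C/c1ccc(C(F)(F)F)cc1`, gives 15400 nM in this assay. Among the measured compounds shown here, the single change between them, (trifluoromethyl in place of nitro on an aromatic carbon), brings an at least 3.2-fold lower number from compound 1 to compound 2 (0.51 log units; beyond the scatter); the step is open-ended because compound 1 sits at the limit of > 50000 nM in this assay, at which 1 of the 3 values shown sits. Compound 3, `COc1cc(OC)c(C(=O)/C=C/c2ccc([N+](=O)[O-])cc2)c(OC)c1`, gives 7100 nM in this assay, the lowest of the two numbers; how its core differs from the core of compound 1 is not broken down here. Compound 4, `COc1cc(OC)c(C(=O)/C=C/c2ccc(C(F)(F)F)cc2)c(OC)c1`, is not yet measured; it differs from compound 3 by trifluoromethyl in place of nitro on an aromatic carbon, the same change as that made from compound 1 to compound 2, at the same place. A lowering of comparable size is expected, a 2.8-fold lower number from compound 3 to compound 4 (0.45 log units; beyond the scatter), resting on the measured step of an at least 3.2-fold lower number from compound 1 to compound 2 (0.51 log units; beyond the scatter), although that earlier step is known only as a bound. Compound 4 is accordingly estimated at 2500 nM in this assay, with a range from 800 nM to 8000 nM.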

Compound 4, half-maximal inhibitory concentration: 14200 nM
The estimate for compound 4 lay 5.7-fold (0.75 log units) below the measured number; the measured number lies above the stated range.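

In this assay, trifluoromethyl in place of nitro on an aromatic carbon does not carry over from the core of compound 1 to the core of compound 3 as a fixed step: here it reads a 2.0-fold higher number from compound 3 to compound 4 (0.30 log units; within the scatter), which leaves compound 3 and compound 4 within the scatter of each other. The two steps differ even though the earlier one is open-ended: the same change on two cores in this assay, an at least 3.2-fold lower number (0.51 log units; beyond the scatter) from compound 1 to compound 2 and a 2.0-fold higher number (0.30 log units; within the scatter) from compound 3 to compound 4, at least 6.4-fold (0.81 log units) apart, beyond the scatter of two such steps. This shows that the step depends on the core in this small set, but it gives neither a reason for that nor the true size of the earlier step, and compound 1 is known only through a limit: the limit of > 50000 nM in this assay, at which 1 of the 4 values shown sits.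

The compounds shown leave open how the same change would behave on any further core, since only two cores are compared here. They also leave open whether an amine, a nitrile or a carboxylic acid on that aromatic carbon would give a step that holds across both cores.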